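The source may hold more compounds than are shown below. What is called first, only, known or untested is meant among the compounds shown, and "the series" means these compounds.

Working notes on the series. The three measured amides share one core and differ only in the aryl group on an aromatic nitrogen. In a functional assay on MGC-803 cells (Homo sapiens) for inhibition, read by MTT assay, with a stated time of 72 h (on this read-out higher numbers stand for weaker inhibition and lower numbers for stronger inhibition), compound 1 `CC(C)n1ncc2c(C(=O)NCc3cn(-c4ccc(F)cc4)nn3)cccc21` gives > 40000 nM, which is a limit of the assay and not a number. Compound 2 `Cc1ccc(-n2cc(CNC(=O)c3cccc4c3cnn4C(C)C)nn2)cc1` likewise returns only the limit > 40000 nM in this assay. Compound 3 `Cc1ccccc1-n1cc(CNC(=O)c2cccc3c2cnn3C(C)C)nn1` also gives just the limit > 40000 nM in this assay. The steps a step that the two limits leave unreadable from compound 2 to compound 1, a step that the two limits leave unreadable from compound 1 to compound 3 and a step that the two limits leave unreadable from compound 2 to compound 3 are therefore unreadable, because every value sits at the limit of > 40000 nM in this assay, at which 3 of the 3 values shown sit. The change from compound 2 to compound 1 is fluoro in place of methyl on an aromatic carbon. The cores of compound 2 and compound 3 differ by 2-methylphenyl in place of 4-methylphenyl on an aromatic nitrogen.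

Compound 4 `CC(C)n1ncc2c(C(=O)NCc3cn(-c4ccccc4F)nn3)cccc21` is not yet measured. It differs from compound 3 by fluoro in place of methyl on an aromatic carbon, the same kind of change as fluoro in place of methyl on an aromatic carbon, but here ortho to a large group rather than para to a large group. The earlier step that the two limits leave unreadable from compound 2 to compound 1 left no readable size, so there is no measured guide for the new one. The step that the limit leaves unreadable from compound 3 to compound 4 is expected to be negligible. Compound 4 is expected to give 60000 nM in this assay, most likely again only a limit, within 20000 nM to 200000 nM.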

Compound 4, half-maximal inhibitory concentration: > 40000 nM
Compound 4 ended at the assay's limit (the forecaster's own chance of this, stated with the estimate: 85%); the middle value is on the limit's open side.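

Compound 4 also returns only a limit, so the steps linking compound 1, compound 2 and compound 3 to compound 4 cannot be read, because all values rest at one limit: the limit of > 40000 nM in this assay, at which 4 of the 4 values shown sit.

The compounds shown leave open how large the fluoro-for-methyl step is and whether any aryl group on this shared core gives a value within the range of this assay.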